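Allyl to propyl on an inactive pair

The source may hold more compounds than are shown below. What is called first, only, known or untested is meant among the compounds shown, and "the series" means these compounds.

In a functional assay on KB cells (Homo sapiens) for inhibition (a lower number here means a stronger inhibitor, a higher number a weaker inhibitor), compound 1 `C=CCn1c(N)c(C#N)c2c(N)ncnc21` gives > 100000 nM, which is a limit and not a number. Compound 2 `COCCOCn1c(Br)c(C#N)c2c(N)ncnc21` gives > 100000 nM, also a limit. Compound 1 therefore stands with compound 2 at the limit of > 100000 nM in this assay, at which 2 of the 2 values shown sit. Compound 3 `CCCn1c(N)c(C#N)c2c(N)ncnc21` differs from compound 1 by ethyl in place of vinyl on a saturated chain carbon bound to an aromatic nitrogen, which reads as allyl to propyl. Going by the values given here, no step between measured compounds is available, so the expectation rests on compound 1 alone, with its limit of > 100000 nM. The estimated step of a number no higher from compound 1 to compound 3 (the limit leaves the size open) is expected to be none beyond the scatter in this assay. For compound 3 the expected value is 100000 nM, with an estimated range of 40000 nM to 250000 nM.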

Compound 3, half-maximal inhibitory concentration: 15000 nM
The estimate for compound 3 lay 6.7-fold (0.82 log units) above the measured number; measured number below the stated range.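

In this assay the step of an at least 6.6-fold lower number from compound 1 to compound 3 (0.82 log units; beyond the scatter) shows that this saturated chain carbon bound to an aromatic nitrogen responds to the change from allyl to propyl. Going by these compounds alone, the change swaps vinyl for ethyl with no change in heavy-atom count, so losing the double bond outside aromatic rings is the only difference in this pair. Compound 3 is the only compound shown to give a number and not a limit: the limit of > 100000 nM in this assay, at which 2 of the 3 values shown sit.

Going by these compounds, compound 1 carries only a limit, so the full size of the step stays open. Also open, on these data alone, is whether a longer chain such as butyl, or a chain ending in an amine, would give a lower number than compound 3 on the same core.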